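This account rests on a few compounds, and the source may have more. Where it says the series, first, only, none or still open, it means among the compounds named here.

Measured so far in an assay on CHO cells for displacement of a labelled ligand from adenosine receptor A3 (Homo sapiens), read by radioligand binding; a lower number here means a stronger inhibitor, a higher number a weaker inhibitor: compound 1 `CCOc1cccc2cc(-c3ccccc3)c(=O)oc12` gives 22500 nM and compound 3 `O=c1oc2c(O)cccc2cc1-c1ccc(Br)cc1` gives 258 nM. Compound 2 `CCOc1cccc2cc(-c3ccc(Br)cc3)c(=O)oc12` reaches only a limit of this assay, > 100000 nM.

Compound 2 therefore stands at the weak end of these numbers, sitting at the assay's limit (the limit of > 100000 nM in this assay, at which 1 of the 3 values shown sits), so no exact number is known for it. Compound 4 `CCOc1cccc2cc(-c3ccc(OC)cc3)c(=O)oc12` differs from compound 2 by methoxy in place of bromo on an aromatic carbon. The step that bears on this position is an at least 4.4-fold higher number from compound 1 to compound 2 (0.64 log units; beyond the scatter), where bromo in place of hydrogen weakened binding. The step of an at least 380-fold lower number from compound 2 to compound 3 (2.58 log units; beyond the scatter) concerns a different change, hydrogen in place of ethyl on an oxygen on an aromatic ring, and says little here. Among the compounds with values here, no measured step shows a methoxy at this position, so the expectation rests mainly on removing the bromo. A modest lowering is therefore expected, an at least 3.3-fold lower number from compound 2 to compound 4 (0.52 log units; beyond the scatter). Compound 4 is estimated at about 30000 nM, likely between 8000 nM and 120000 nM.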

Compound 4, inhibition constant: 5320 nM
Beside the measured number, compound 4's estimate is 5.6-fold (0.75 log units) above it; the measured number lies below the stated range.
By their numbers in this assay, from the lowest: compound 3; then compound 4; then compound 1. At a limit, above all of these: compound 2.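

In this assay, methoxy in place of hydrogen gives a 4.2-fold lower number from compound 1 to compound 4 (0.63 log units; beyond the scatter), so a group on this carbon can strengthen binding, whereas bromo had only weakened it. Methoxy in place of bromo gives an at least 18-fold lower number from compound 2 to compound 4 (1.27 log units; beyond the scatter), which shows that the identity of the group matters, not just the presence of one. The exact size of that step is unknown because compound 2 is only a limit: the limit of > 100000 nM in this assay, at which 1 of the 4 values shown sits.

On these data alone, it remains open whether an amine or a carboxylic acid at this position would behave like methoxy or like bromo. Also open, as far as these compounds go, is how methoxy here would combine with hydrogen in place of ethyl on the oxygen.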